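A few compounds are considered here, and "the series" means these few. Any claim that something is new, unique, unknown or untested is made for them only; others in the source may bear on it.

Working notes on the series.

Compound 1 `CN(C(=O)c1c(O)c2c(C(F)(F)F)cccc2n(C)c1=O)c1ccccc1` is the reference. Among the compounds with values here, in a functional assay on the whole organism for inhibition, with Mus musculus as the target, at a dose of 1 mg/kg by the oral route (on this read-out lower numbers stand for less inhibition and higher numbers for more inhibition at the one dose given (going by the name of the read-out)), compound 1 gives 99%, the highest of the three numbers so far. Within the data shown here, compound 2 `CCN(C(=O)c1c(O)c2c(C(F)(F)F)cccc2n(C)c1=O)c1ccccc1` gives 80% in this assay, and the step of a number 19 percentage points lower from compound 1 to compound 2 (beyond the scatter) is the only single-point change measured; it concerns the amide side and not the aromatic ring, so it does not bear directly on the change at hand. Among the measured compounds shown here, compound 3 `COc1cccc2c1c(O)c(C(=O)N(C)c1cccc(Cl)c1)c(=O)n2C` gives 85%; it differs from compound 1 in two places, with methoxy in place of trifluoromethyl on the fused ring and a chloro on the phenyl, so no single step can be drawn, but its value shows that losing trifluoromethyl at that position still leaves strong inhibition.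

Compound 4 `CN(C)c1cccc2c1c(O)c(C(=O)N(C)c1ccccc1)c(=O)n2C` differs from compound 1 by dimethylamino in place of trifluoromethyl on an aromatic carbon. For the measured compounds named here, no measured step covers this exact exchange. Going by compound 3, whose value 85% stays high without trifluoromethyl, a modest lowering from the high number of compound 1 is expected, with compound 4 estimated at 85% (range 60% to 99%), an expected step of a number 14 percentage points lower from compound 1 to compound 4 (beyond the scatter).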

Compound 4, a percentage reported as inhibition, in the whole organism at one dose (the size of the read-out at that dose, not a potency): 93%
For compound 4 the middle estimate is 8 percentage points below the measured one; measured number inside the range.
By their numbers in this assay, from the lowest: compounds 2, 3, 4 and 1 (each within the scatter of the next, the first and the last beyond it).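

In this assay, dimethylamino in place of trifluoromethyl on this aromatic carbon gives a number 6 percentage points lower from compound 1 to compound 4 (within the scatter). Within the data shown here, this is the first reading of an exchange at this place alone, with the rest of the core of compound 1 kept, and it shows that trifluoromethyl is not required there for strong inhibition at the one dose given, as a group of carbon and nitrogen serves within the scatter. No measurement is available that would explain this result.

Open, as far as these compounds go, is whether the same holds for a carboxylic acid, a primary amine or a longer chain such as n-butyl on this aromatic carbon. From the compounds shown here alone, a read-out at one dose is also not a potency, so any difference between compound 1 and compound 4 at other doses remains unknown.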